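From compound 3 to compound 4 in the acid chain

The source may report more compounds than this note shows. Statements on the series, on what has been measured and on what is new or still open speak of the compounds shown alone.

In an ADME assay on the whole organism (strain CD-1) for metabolic stability, with Mus musculus as the target, at a dose of 3 mg/kg by the intravenous route (a lower number here means that the compound disappears faster, a higher number that the compound lasts longer), compound 1 `C[C@H](CCCOc1ccccc1CN(C)C(=O)c1ccc(-c2ccco2)cc1)CC(=O)O` gives 3.9 h while compound 2 `CN(Cc1ccccc1OCCC[C@@H]1C[C@H]1C(=O)O)C(=O)c1ccc(-c2ccco2)cc1` gives 3.5 h and compound 3 `CN(Cc1ccccc1OCCC/C=C/C(=O)O)C(=O)c1ccc(-c2ccco2)cc1` gives 1.9 h as its half-life. The step of a 2.1-fold lower number from compound 1 to compound 3 (0.31 log units; beyond the scatter) is the only one beyond the scatter. The steps of a 1.8-fold lower number from compound 2 to compound 3 (0.27 log units; within the scatter) and a 1.1-fold lower number from compound 1 to compound 2 (0.05 log units; within the scatter) stay within it, so compound 3 stands clear of compound 1 only and cannot be told from compound 2.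

Compound 4 `C/C(=C\CCCOc1ccccc1CN(C)C(=O)c1ccc(-c2ccco2)cc1)C(=O)O` differs from compound 3 by 2-carboxyprop-1-en-1-yl in place of 2-carboxyethenyl on a saturated chain carbon, three bonds along the chain from an oxygen on an aromatic ring with 2-carboxyprop-1-en-1-yl in place of 2-carboxyethenyl on a saturated chain carbon, three bonds along the chain from an oxygen on an aromatic ring. Among the compounds with values here, no measured step makes this exact change, but all three swap groups at the same place. The largest of them, a 2.1-fold lower number from compound 1 to compound 3 (0.31 log units; beyond the scatter) only just passes the scatter, so no step beyond the scatter is expected in this assay in either direction. The expected step is a 1.3-fold higher number from compound 3 to compound 4 (0.10 log units; within the scatter) and no more than that is estimated. For compound 4 the estimate is 2.4 h with an expected range from 1.3 h to 4.4 h in this read-out.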

Compound 4, half-life: 1.2 h
Compound 4: middle estimate off by 2.0-fold (0.30 log units), on the high side, and the stated range ends above it.
By their numbers in this assay, from the lowest: compounds 4, 3, 2 and 1 (each within the scatter of the next, the first and the last beyond it).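

In this assay, the step of a 1.6-fold lower number from compound 3 to compound 4 (0.20 log units; within the scatter) cannot be told from scatter, so 2-carboxyprop-1-en-1-yl and 2-carboxyethenyl do not separate at this place on a saturated chain carbon. Within the data shown here, the other two steps, a 2.9-fold lower number from compound 2 to compound 4 (0.46 log units; beyond the scatter) and a 3.3-fold lower number from compound 1 to compound 4 (0.51 log units; beyond the scatter), both lie beyond the scatter, which makes 2-carboxyprop-1-en-1-yl the first group here to stand clear of 2-carboxycyclopropyl as well as 1-(carboxymethyl)ethyl, whereas compound 3 stood clear of 1-(carboxymethyl)ethyl only. Nothing available accounts for these differences.

Still open, from the compounds shown here alone, is how an amide or a tetrazole would read in place of the carboxylic acid at this place. Also open, going by these compounds, is whether a longer chain from the oxygen on the aromatic ring would shift these half-lives.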